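The source may hold more compounds than are shown below. What is called first, only, known or untested is meant among the compounds shown, and "the series" means these compounds.

Three ureas built on a shared core have been run through a functional assay on HCC827 cells (Homo sapiens) for inhibition, read by MTT assay, with a stated time of 48 h, tested at 10 uM; on this read-out lower numbers stand for less inhibition and higher numbers for more inhibition at the one concentration tested (going by the name of the read-out). Compound 1, `COc1cc(NC(=O)Nc2cc(Nc3cc(Br)ccc3OC)ncn2)cc(OC)c1`, gives 76.3% in this assay and stands highest of the three numbers. Compound 3, `COc1cc(Nc2cc(NC(=O)Nc3c(Cl)cccc3Cl)ncn2)cc(C(F)(F)F)c1`, is the nearest neighbour of compound 1; in this assay compound 3 gives 57.7%, a number beyond the scatter below compound 1. Compound 2, `COc1cc(Br)ccc1Nc1cc(NC(=O)Nc2c(Cl)cccc2Cl)ncn1`, lies furthest away and gives 42.7%, also beyond the scatter below compound 1. Going by the values given here, no pair of these three differs in a single place, so no single-point step between measured compounds can be read from them.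

The next compound, compound 4, `COc1cc(NC(=O)Nc2cc(Nc3cc(F)ccc3OC)ncn2)cc(OC)c1`, has not been measured in this assay. It differs from compound 1 in one place: fluoro in place of bromo on an aromatic carbon. The bromo on that aromatic carbon, meta to a large group and para to a methoxy group, is exchanged for fluoro, so the (5-bromo-2-methoxyphenyl)amino part becomes a (5-fluoro-2-methoxyphenyl)amino part. Among the compounds with values here, no measured pair shows this exchange, so the size of the step can only be estimated from the general run of the three numbers. The expected step is a number 10.3 percentage points lower from compound 1 to compound 4 (beyond the scatter), a small downward move that may well sit within the scatter. Compound 4 is accordingly estimated to give 66% in this assay, with a likely range from 45% to 82%.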

Compound 4, a percentage reported as inhibition, at one concentration (the size of the read-out at that concentration, not a potency): 59%
Compound 4: the middle estimate sits 7 percentage points above what was measured, and the stated range covers the measured number.
By their numbers in this assay, from the lowest: compound 2; then compounds 3 and 4 (each within the scatter of the next); then compound 1.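

Going by these compounds alone, the exchange of bromo for fluoro gives the first step in this set that can be read at a single place: in this assay the move is a number 17.3 percentage points lower from compound 1 to compound 4 (beyond the scatter) and so shows that the halogen on this aromatic carbon, para to a methoxy group, changes the read-out. The earlier compounds shown here could not show this, as each pair among them differs in more than one place. With fluoro at this carbon, compound 4 still gives 59% at the one concentration tested, so the position keeps a sizeable reading with the smaller halogen, and the data shown offer no measurement that would explain the step.

The compounds shown leave open how a group such as a nitrile or a methyl group would read at this same carbon, so a single exchange cannot yet set out a trend for the position. They also leave open whether fluoro in place of bromo would give a step of similar size with the other urea part seen in compound 2.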